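A few compounds are considered here, and "the series" means these few. Any claim that something is new, unique, unknown or untested is made for them only; others in the source may bear on it.

Two compounds share one core and differ only in the group on an aromatic carbon of a five-membered aromatic ring with three nitrogens. Compound 1 `Cc1ccc(S(=O)(=O)NCc2cn(C[C@H](O)[C@H]3OC(=O)C(OCc4ccccc4)=C3OCc3ccccc3)nn2)cc1` gives 68000 nM in a functional assay on CFPAC-1 cells (Homo sapiens) for antiproliferative activity, read by MTT assay, with a stated time of 72 h; a lower number here means a stronger inhibitor, a higher number a weaker inhibitor. Compound 2 `O=C1O[C@H]([C@@H](O)Cn2cc(-c3cccc(O)c3)nn2)C(OCc2ccccc2)=C1OCc1ccccc1` gives 54100 nM in this assay; it sits at the low end of the two numbers recorded, yet the step of a 1.3-fold lower number from compound 1 to compound 2 (0.10 log units; within the scatter) lies within the scatter, so compound 2 and compound 1 cannot be separated. Compound 3 `O=C1O[C@H]([C@@H](O)Cn2cc(-c3cc(F)cc(F)c3)nn2)C(OCc2ccccc2)=C1OCc1ccccc1` carries the change (3,5-difluorophenyl in place of 3-hydroxyphenyl on an aromatic carbon). Among the compounds with values here, the only measured step, a 1.3-fold lower number from compound 1 to compound 2 (0.10 log units; within the scatter), concerns a different exchange on that aromatic carbon and was itself within the scatter, so it gives no direction for the present change; both measured compounds land at closely similar numbers. The step of a 1.1-fold lower number from compound 2 to compound 3 (0.03 log units; within the scatter) is therefore expected to stay within the scatter. Compound 3 is estimated at 50000 nM, with a range from 18000 nM to 140000 nM.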

Compound 3, half-maximal inhibitory concentration: 62400 nM
Estimate against measurement, compound 3: 1.2-fold (0.10 log units) below, and the stated range covers the measured number.
By their numbers in this assay, from the lowest: compounds 2, 3 and 1 (each within the scatter of the next).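

Compound 3 shows that this aromatic carbon tolerates a group with 0 hydrogen-bond donors and 0 hydrogen-bond acceptors in place of 3-hydroxyphenyl, which has 1 of each, without a readable shift in this assay (a 1.2-fold higher number from compound 2 to compound 3 (0.06 log units; within the scatter)). The comparison with the sulfonamide-bearing group gives the same picture (a 1.1-fold lower number from compound 1 to compound 3 (0.04 log units; within the scatter)), so (((4-methylphenyl)sulfonyl)amino)methyl, 3-hydroxyphenyl and 3,5-difluorophenyl cannot be separated at this position. Nothing available accounts for why these numbers stay together.

From the compounds shown here alone, whether an amine or a carboxylic acid on this aromatic carbon would give a number outside this narrow group remains open. Also open, going by these compounds, is whether a change elsewhere on the shared core would move the number in this assay beyond the scatter.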